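Lengthening the alkylamine chain of compound 2

The compounds below may be only part of what the source reports. "The series", "measured", "known", "first", "only" and "open" are said of these compounds alone.

Compound 1 `COc1ccc(CNc2nc(NCc3ccc(OC)cc3)c3ccccc3n2)cc1`: 3870 nM
Compound 2 `CCNc1nc(SCC)nc2ncccc12`: 20100 nM
Compound 3 `Cc1ccc(CNc2nc(NCc3ccc(C)cc3)c3cccnc3n2)cc1`: 5000 nM

Of the compounds shown here, three have been measured in a functional assay on T-24 cells (Homo sapiens) for cytotoxicity, read by neutral red uptake, with a stated time of 72 h; a lower number here means a stronger inhibitor, a higher number a weaker inhibitor. Compound 1, with its two methoxybenzylamino arms, gives 3870 nM. Compound 3, carrying two methylbenzylamino arms on a different core, gives 5000 nM. Compound 2, a small molecule with an ethylamino and an ethylthio substituent, gives 20100 nM, the highest of the three numbers; the gap to compound 3 and the larger gap to compound 1 both lie beyond the usual scatter, so compound 2 stands as the weakest of the measured set in this assay.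

The next compound, compound 4 `CCCCCCCNc1nc(SCC)nc2ncccc12`, differs from compound 2 in one place: pentyl in place of hydrogen on a saturated chain carbon, two bonds along the chain from a nitrogen on an aromatic ring. Read one bond further out, the ethyl on the amine nitrogen becomes a heptyl. For the measured compounds named here, no step between two measured compounds speaks to this kind of change, so the expectation rests only on the weak starting point of compound 2 at 20100 nM and on the modest size of the alteration. A small gain in potency is expected, with the step from compound 2 to compound 4 estimated as a 2.5-fold lower number from compound 2 to compound 4 (0.40 log units; beyond the scatter), though a result within the scatter would not surprise. Compound 4 is therefore estimated at 8000 nM, with a range from 2500 nM to 25000 nM.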

Compound 4, half-maximal inhibitory concentration: 5300 nM
Beside the measured number, compound 4's estimate is 1.5-fold (0.18 log units) above it; the measured number falls inside the stated range.
By their numbers in this assay, from the lowest: compounds 1, 3 and 4 (each within the scatter of the next); then compound 2.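

In this assay, placing pentyl in place of hydrogen on a saturated chain carbon, two bonds along the chain from a nitrogen on an aromatic ring, gives a 3.8-fold lower number from compound 2 to compound 4 (0.58 log units; beyond the scatter) and provides the only step among these compounds that isolates a single change. It shows that this chain is not confined to ethyl: read one bond further out, the change from ethyl to heptyl goes with a lower number, not a higher one, while the ethylthio group and the shared core stay the same. Nothing available explains why the number moves with this change.

From the compounds shown here alone, a single pair gives two chain lengths and no trend, so it remains open whether a propyl or butyl chain would already give much of this shift, and whether a longer chain such as decyl would extend it or reverse it. Going by these compounds, it is equally open how a chain ending in a hydroxyl group, an amine or a carboxylic acid would compare with the plain heptyl, and whether replacing the ethylthio group with a longer thioether would give a step of similar size.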